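Difluorophenyl Replaces Methoxyphenyl on the Carbonyl Carbon

The source may hold more compounds than are shown below. What is called first, only, known or untested is meant among the compounds shown, and "the series" means these compounds.

Compound 2 `COc1ccc(C(=O)/C=C/c2cc(-c3cc(OC)c(OC)c(OC)c3)n[nH]2)cc1` gives 102% in a functional assay on ACHN cells (Homo sapiens) for cytotoxicity, read by sulforhodamine B assay, with a stated time of 48 h, tested at 0.01 uM; a lower number here means a stronger effect, a higher number a weaker effect of the compound at the concentration tested. Among the measured compounds shown here, compound 1 `COc1cc(-c2cc(/C=C/C(=O)c3ccc(Cl)c(Cl)c3)[nH]n2)cc(OC)c1OC`, the only other measured compound, gives 107% in this assay, so the two sit alongside each other within the scatter. Compound 3 `COc1cc(-c2cc(/C=C/C(=O)c3ccc(F)c(F)c3)[nH]n2)cc(OC)c1OC` differs from compound 2 by 3,4-difluorophenyl in place of 4-methoxyphenyl on a carbonyl carbon. For the measured compounds named here, the one step that bears on this place is a number 5 percentage points lower from compound 1 to compound 2 (within the scatter); exchanging one ring on that carbon for another left the read-out essentially unchanged. A change of similar character is therefore expected to give no step beyond the scatter, a number 2 percentage points higher from compound 2 to compound 3 (within the scatter). Compound 3 is estimated at 104%, between 90% and 116%.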

Compound 3, a percentage reported as activity, at one concentration (the size of the read-out at that concentration, not a potency): 102%
For compound 3 the middle estimate is 2 percentage points above the measured one; the range from low to high includes it.
By their numbers in this assay, from the lowest: compounds 2, 3 and 1 (each within the scatter of the next).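

In this assay three different rings now stand on the carbonyl carbon: 3,4-difluorophenyl in place of 4-methoxyphenyl gives no change at the digits printed from compound 2 to compound 3 (within the scatter) and in place of 3,4-dichlorophenyl gives a number 5 percentage points lower from compound 1 to compound 3 (within the scatter) for the same exchange on this carbon. Fluorine, chlorine and methoxy groups on this ring therefore leave the read-out level, and no compound stands apart. No measurement shown offers an explanation for this flat result. Still open, as far as these compounds go, is whether a ring carrying an amine or a carboxylic acid, or a longer chain instead of a ring, would shift the number. From the compounds shown here alone, how these three compounds behave at higher concentrations also remains open.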